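The compounds below may be only part of what the source reports. "The series", "measured", "known", "first", "only" and "open" are said of these compounds alone.

In a functional assay on HepG2 cells (Homo sapiens) for antiproliferative activity, read by MTT assay, with a stated time of 72 h (a higher number here means a weaker inhibitor, a lower number a stronger inhibitor), compound 1 (`COc1ccc(N2C(=O)COc3ccc(-c4ccc(O)cc4)cc32)cc1`) gives 10800 nM and so holds the higher of the two actual numbers in this small set. Compound 3 (`COc1cccc(N2C(=O)COc3ccc(-c4cnc5ccccc5c4)cc32)c1`) gives 2080 nM as the lower of the two, and the gap between them lies beyond the scatter. Compound 2 (`COc1ccc(N2C(=O)COc3ccc(-c4cnc(Cl)c(NS(=O)(=O)c5ccc(F)cc5)c4)cc32)cc1`) has no number at all, only > 40000 nM as a limit of the measurement.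

The step followed here leads from compound 1 to compound 4 (`O=C1COc2ccc(-c3ccc(O)cc3)cc2N1`), which has not yet been measured. The structural change is counted as follows (hydrogen in place of 4-methoxyphenyl on an amide-type nitrogen in a ring): hydrogen in place of 4-methoxyphenyl on an amide-type nitrogen in a ring. Every measured compound carries a methoxy-bearing phenyl ring on that nitrogen, so none of them shows what the bare nitrogen does.

With compound 1 at 10800 nM as the starting point, a step in this assay toward weaker inhibition is expected, moderate in size but beyond the scatter. The expected change is a 2.3-fold higher number from compound 1 to compound 4 (0.36 log units; beyond the scatter) in that direction. The estimated value for compound 4 is 25000 nM with an expected range of 9000 nM to 70000 nM overall.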

Compound 4, half-maximal inhibitory concentration: 38200 nM
Compound 4: the middle estimate sits 1.5-fold (0.18 log units) below what was measured; the measured number falls inside the stated range.
By their numbers in this assay, from the lowest: compound 3; then compound 1; then compound 4. At a limit, above all of these: compound 2.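

In this assay, going by these compounds alone, hydrogen in place of 4-methoxyphenyl on the amide-type nitrogen gives a 3.5-fold higher number from compound 1 to compound 4 (0.55 log units; beyond the scatter); this is the first reading of that position without an aryl group, as every earlier compound carried a methoxy-bearing phenyl ring there. The change therefore weakens inhibition by a modest step, but it does not abolish it, and compound 4 still returns an actual number of 38200 nM. Compound 2 reads only as a limit, and so the top of the range reported here is close to compound 4: the limit of > 40000 nM in this assay, at which 1 of the 4 values shown sits.

The compounds shown do not tell whether a methyl, an ethyl or an unsubstituted phenyl on that nitrogen would give a number nearer to compound 1 or to compound 4, so the step cannot be divided between the phenyl ring and its methoxy group. They also leave open whether the same replacement would have a similar effect on the core of compound 3, which differs from compound 1 in more than one place.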